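Dimethylphenyl Amide in a Dibenzoylhydrazine Ecdysone Agonist Series

A few compounds are considered here, and "the series" means these few. Any claim that something is new, unique, unknown or untested is made for them only; others in the source may bear on it.

Compound 1 `CC(C)(C)N(NC(=O)c1ccc(F)cc1)C(=O)c1ccccc1Cl` gives 389 nM in an assay on cells for agonist activity at ecdysone receptor (Bombyx mori), read by a luciferase reporter, with a stated time of 24 h (a higher number here means that more compound is needed for the effect, a lower number that less compound is needed), the highest of the three numbers shown. Compound 2 `CCCc1ccc(C(=O)NN(C(=O)c2ccccc2Cl)C(C)(C)C)cc1` gives 9.12 nM and compound 3 `CC(C)c1ccc(C(=O)NN(C(=O)c2ccccc2Cl)C(C)(C)C)cc1` gives 24.6 nM; the steps of a 43-fold lower number from compound 1 to compound 2 (1.63 log units; beyond the scatter) and a 16-fold lower number from compound 1 to compound 3 (1.20 log units; beyond the scatter) are both large, while a 2.7-fold higher number from compound 2 to compound 3 (0.43 log units; beyond the scatter) is modest. Compound 4 `Cc1cccc(C(=O)NN(C(=O)c2ccccc2Cl)C(C)(C)C)c1C` differs from compound 1 by 2,3-dimethylphenyl in place of 4-fluorophenyl on a carbonyl carbon. The measured steps replaced fluoro on an aromatic carbon with an alkyl group; compound 4 instead exchanges the whole aryl group, so those steps bear only in part. A lower number is still expected for compound 4, at 100 nM, with a range of 20 nM to 600 nM. The expected step is a 3.9-fold lower number from compound 1 to compound 4 (0.59 log units; beyond the scatter).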

Compound 4, half-maximal effective concentration: 20 nM
The estimate for compound 4 lay 5.0-fold (0.70 log units) above the measured number, within the range that was stated.
By their numbers in this assay, from the lowest: compound 2; then compounds 4 and 3 (each within the scatter of the next); then compound 1.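

The step of a 19-fold lower number from compound 1 to compound 4 (1.29 log units; beyond the scatter) shows that the whole aryl group on this carbonyl carbon can be exchanged, not only a single substituent, and that a large drop in the number follows. In this change the fluorine leaves and two methyl groups enter together, so the two cannot be separated. No measurement given here bears on why the number falls.

The compounds shown leave open whether a single methyl group, as in 3-methylphenyl, would give the same step. They also leave open how an amine or a carboxylic acid on this aryl ring would read.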